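Swapping a Urea for a Carbamate on a Piperazine Tail

The source may report more compounds than this note shows. Statements on the series, on what has been measured and on what is new or still open speak of the compounds shown alone.

Of the compounds shown here, three sharing one core have been tested in an ADME assay on cells (Hepatocyte, Rattus norvegicus) for metabolic stability; a higher number here means faster removal of the compound, a lower number slower removal. Compound 1, `CN(C)[C@H]1CC[C@H](Nc2ncnc3[nH]cc(C4CC4)c23)CC1`, carries a cyclopropyl group on the core and gives 15 uL/min. Compound 2, `CN(C)[C@H]1CC[C@H](Nc2ncnc3[nH]cc(C4CCCO4)c23)CC1`, carries an oxolane ring in the same position; its repeated entries read 59 uL/min; 36 uL/min (2 entries), and the spread between them, shown in the several entries of compound 2 in this assay, 59 uL/min; 36 uL/min (2 entries), illustrates how far repeat measurements of this kind can fall apart. Compound 3, `CN(C)C(=O)N1CCN([C@H]2CC[C@H](Nc3ncnc4[nH]cc(C5CCOCC5)c34)CC2)CC1`, is larger, with a dimethylcarbamoyl piperazine on the cyclohexyl ring, and gives 13 uL/min. Compound 3 and compound 1 sit within the scatter of each other, so neither can be called slower or faster; the entries of compound 2 lie higher than both.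

Compound 4, `COC(=O)N1CCN([C@H]2CC[C@H](Nc3ncnc4[nH]cc(C5CCOCC5)c34)CC2)CC1`, has not yet been measured in this assay. It differs from compound 3 in a single place: methoxy in place of dimethylamino on a carbonyl carbon. The change sits on the carbonyl carbon whose other neighbour is the amide-type nitrogen in the ring, far from the part of the molecule that varies between compounds 1, 2 and 3. Going by the values given here, with no measured pair of this kind to lean on, the step is expected to stay within the scatter, in either direction. Compound 4 is therefore estimated at 16 uL/min, with a likely range of 7 uL/min to 40 uL/min, corresponding to an expected 1.2-fold higher number from compound 3 to compound 4 (0.09 log units; within the scatter).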

Compound 4, intrinsic clearance in a liver preparation (reported as CLH), per the amount of preparation that the assay uses: 17 uL/min
The estimate for compound 4 lay 1.1-fold (0.03 log units) below the measured number; measured number inside the range.
By their numbers in this assay, from the lowest: compounds 3, 1 and 4 (each within the scatter of the next).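

Going by these compounds alone, this is the first pair here that differs in one place, so it isolates a single replacement on a carbonyl carbon whose other neighbour is an amide-type nitrogen in a ring. In this assay, methoxy in place of dimethylamino gives a 1.3-fold higher number from compound 3 to compound 4 (0.12 log units; within the scatter), so the 4-(dimethylcarbamoyl)piperazin-1-yl and 4-(methoxycarbonyl)piperazin-1-yl tails cannot be told apart in this pair. A step of this size cannot be read as a real difference in removal because repeat entries for a single compound can themselves lie this far apart or further: the several entries of compound 2 in this assay, 59 uL/min; 36 uL/min (2 entries)

The compounds shown leave open how other groups on the same carbonyl carbon would read in this assay, such as ethoxy, a longer chain such as tert-butoxy, or a cyclic amine such as pyrrolidine. Within the data shown here, they also leave open whether methoxy and dimethylamino would still read alike on this tail if the group on the shared core were a cyclopropyl or oxolane ring, as in compound 1 and compound 2, rather than the one that compound 3 and compound 4 carry.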